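Methyl in place of methoxy: what to expect

The source may report more compounds than this note shows. Statements on the series, on what has been measured and on what is new or still open speak of the compounds shown alone.

Of the compounds shown here, two have been measured in a functional assay on the whole organism (strain Swiss albino) for inhibition, with Mus musculus as the target, with a stated time of 4 h; on this read-out lower numbers stand for an effect already at smaller amounts and higher numbers for an effect only at larger amounts of compound. Compound 1 `COc1ccc(-n2c(Nc3nc(-c4ccc([N+](=O)[O-])cc4)cs3)n[nH]c2=S)cc1` gives 300 mg/kg, and compound 2 `COc1ccc(-n2c(Nc3nc(-c4ccccc4)cs3)n[nH]c2=S)cc1` gives 100 mg/kg, the lower of the two numbers; between them there is a 3.0-fold lower number from compound 1 to compound 2 (0.48 log units; beyond the scatter). Compound 3 `Cc1ccc(-n2c(Nc3nc(-c4ccccc4)cs3)n[nH]c2=S)cc1` differs from compound 2 by methyl in place of methoxy on an aromatic carbon. Within the data shown here, the single measured step concerns a different group at a different place, so no measured step bears on this change. An effect beyond the scatter in this assay is therefore not expected in either direction; the estimated step is no change at the digits printed from compound 2 to compound 3 (within the scatter). For compound 3 the estimate in this assay is 100 mg/kg, within a range from 50 mg/kg to 300 mg/kg.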

Compound 3, minimum effective dose: 300 mg/kg
The estimate for compound 3 lay 3.0-fold (0.48 log units) below the measured number; measured number inside the range.
By their numbers in this assay, from the lowest: compound 2; then compounds 1 and 3 (each within the scatter of the next).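

In this assay, methyl in place of methoxy gives a 3.0-fold higher number from compound 2 to compound 3 (0.48 log units; beyond the scatter) and is beyond the scatter, so the group on this six-membered aromatic ring does affect the read-out. With 4-methoxyphenyl, the number is lower than with 4-methylphenyl in this pair, which differs in one place only. No measured property is available to account for this step.

The compounds shown leave open how a hydroxyl group, an ethoxy chain or a chlorine atom would read at this place. They also leave open whether the same step would appear with the nitro group of compound 1 present.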